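Methyl in place of trifluoromethyl on compound 2

The source may hold more compounds than are shown below. What is called first, only, known or untested is meant among the compounds shown, and "the series" means these compounds.

Compound 2, with the structure `Cc1c(CN2CCCC2)cc(-c2ccc(C(F)(F)F)cc2)n1Nc1ccnc2cc(Cl)ccc12`, is the more lipophilic of the two measured compounds in a physicochemical assay for lipophilicity, at pH 5.2 (a lower number here means a more polar compound, a higher number a more lipophilic compound), where compound 2 gives 4.72. Compound 1, `Cc1c(CN2CCCC2)cc(-c2ccccc2)n1Nc1ccnc2cc(Cl)ccc12`, gives 3.28 in this assay, and the step of a number 1.44 log units higher from compound 1 to compound 2 (beyond the scatter) separates the two. Compound 3, `Cc1ccc(-c2cc(CN3CCCC3)c(C)n2Nc2ccnc3cc(Cl)ccc23)cc1`, has not yet been measured in this assay. It differs from compound 2 in one place: methyl in place of trifluoromethyl on an aromatic carbon. Going by the values given here, the only measured step that bears on this change is the one from compound 1 to compound 2, in which a hydrogen became a trifluoromethyl on the same aromatic carbon and the number rose by a number 1.44 log units higher from compound 1 to compound 2 (beyond the scatter). Compound 3 carries a methyl there instead, which is neither the hydrogen of compound 1 nor the trifluoromethyl of compound 2, so compound 3 is expected to fall between them, though nearer to compound 2 than to compound 1. The step from compound 2 to compound 3 is therefore expected to be a modest decrease, a number 0.47 log units lower from compound 2 to compound 3 (beyond the scatter), beyond the scatter but smaller than the measured step. For compound 3 the estimate in this assay is 4.25, with a range from 3.75 to 4.75.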

Compound 3, distribution coefficient: 3.91
Beside the measured number, compound 3's estimate is 0.34 log units above it; the measured number falls inside the stated range.
By their numbers in this assay, from the lowest: compound 1; then compound 3; then compound 2.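

With a third group at this aromatic carbon, para to a large group, the position no longer rests on a single comparison of hydrogen and trifluoromethyl. Methyl in place of hydrogen gives a number 0.63 log units higher from compound 1 to compound 3 (beyond the scatter), and methyl in place of trifluoromethyl gives a number 0.81 log units lower from compound 2 to compound 3 (beyond the scatter), so in this assay the methyl compound stands apart from both neighbours and the three groups give three separate levels, in the order hydrogen, methyl, trifluoromethyl. The change of a single substituent at this carbon, even one as small as methyl, is thus enough to move the number beyond the scatter in either direction, and no measurement shown here explains why the three groups fall in this order.

The compounds shown leave open where other groups at this carbon would fall, such as a chlorine, a methoxy, an amine or a carboxylic acid, and whether any of them would land outside the span set by hydrogen and trifluoromethyl. They also leave open whether the same order of hydrogen, methyl and trifluoromethyl would hold at another carbon of this ring or on a different core.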